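Isopropyl to ethyl on the sulfonamide nitrogen

The compounds below may be only part of what the source reports. "The series", "measured", "known", "first", "only" and "open" are said of these compounds alone.

In a functional assay on BXPC-3 cells (Homo sapiens) for inhibition, read by MTT assay, with a stated time of 7 days (on this read-out lower numbers stand for stronger inhibition and higher numbers for weaker inhibition), compound 1 `CC(C)c1noc(N2CCN(C(=O)[C@@H]3CCCN(S(=O)(=O)c4ccc(S(=O)(=O)NC5CC5)cc4)C3)CC2)n1` gives 6700 nM and compound 2 `CC(C)NS(=O)(=O)c1ccc(S(=O)(=O)N2CCC[C@@H](C(=O)N3CCN(c4nc(C(C)C)no4)CC3)C2)cc1` gives 2600 nM, the lower of the two numbers. Compound 3 `CCNS(=O)(=O)c1ccc(S(=O)(=O)N2CCC[C@@H](C(=O)N3CCN(c4nc(C(C)C)no4)CC3)C2)cc1` differs from compound 2 by hydrogen in place of methyl on a saturated chain carbon bound to a saturated chain carbon and a sulfonamide nitrogen, with hydrogen in place of methyl on a saturated chain carbon bound to a saturated chain carbon and a sulfonamide nitrogen, turning isopropyl to ethyl. Going by the values given here, the only measured step bearing on this is modest: a 2.6-fold lower number from compound 1 to compound 2 (0.41 log units; beyond the scatter). A smaller move towards a higher number is therefore expected in this assay, probably within the scatter. The expected step is a 1.5-fold higher number from compound 2 to compound 3 (0.16 log units; within the scatter). The estimate for compound 3 is 3800 nM, with an expected range of 1700 nM to 8500 nM.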

Compound 3, half-maximal inhibitory concentration: 6900 nM
Compound 3: the middle estimate sits 1.8-fold (0.26 log units) below what was measured, and the stated range covers the measured number.
By their numbers in this assay, from the lowest: compound 2; then compounds 1 and 3 (each within the scatter of the next).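

In this assay the change from isopropyl to ethyl on the sulfonamide nitrogen gives a 2.7-fold higher number from compound 2 to compound 3 (0.42 log units; beyond the scatter) and so is not neutral: the loss of one methyl at this position is enough to register. Ethyl and cyclopropyl on that nitrogen show a 1.0-fold higher number from compound 1 to compound 3 (0.01 log units; within the scatter) and cannot be told apart, so among these three compounds only isopropyl stands apart. No evidence to hand accounts for this difference.

Open, from the compounds shown here alone, is whether a tert-butyl group, a longer chain such as n-propyl, or the unsubstituted sulfonamide on this nitrogen would extend the gain seen with isopropyl or lose it.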